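Sulfonamide nitrogen substituents on a thiourea series

The source may report more compounds than this note shows. Statements on the series, on what has been measured and on what is new or still open speak of the compounds shown alone.

Measured compounds in a functional assay on HeLa cells (Homo sapiens) for antiproliferative activity, read by sulforhodamine B assay, with a stated time of 48 h; a lower number here means a stronger inhibitor, a higher number a weaker inhibitor:
- compound 1 `NS(=O)(=O)c1ccc(N/C(S)=N\c2ccnc3cc(C(F)(F)F)ccc23)cc1`: 36600 nM
- compound 2 `N=C(N)NS(=O)(=O)c1ccc(N/C(S)=N\c2ccnc3cc(C(F)(F)F)ccc23)cc1`: 23900 nM
- compound 3 `COc1cc(NS(=O)(=O)c2ccc(N/C(S)=N\c3ccnc4cc(C(F)(F)F)ccc34)cc2)nc(OC)n1`: 53800 nM

Compound 3 gives the highest of the three numbers in this assay. Its nearest neighbour is compound 1, a step that stays within the scatter a 1.5-fold higher number from compound 1 to compound 3 (0.17 log units; within the scatter); the gap to compound 2 is the only one beyond the scatter and is modest a 2.3-fold higher number from compound 2 to compound 3 (0.35 log units; beyond the scatter). The step from the unsubstituted sulfonamide to the guanidine-bearing one is also within the scatter a 1.5-fold lower number from compound 1 to compound 2 (0.19 log units; within the scatter).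

Compound 4 `COc1ncnc(NS(=O)(=O)c2ccc(N/C(S)=N\c3ccnc4cc(C(F)(F)F)ccc34)cc2)c1OC` is an isomer of compound 3: 5,6-dimethoxypyrimidin-4-yl in place of 2,6-dimethoxypyrimidin-4-yl on a sulfonamide nitrogen. Going by the values given here, no measured step changes the substitution pattern within a ring on the sulfonamide nitrogen; the two steps that lead into compound 3 only swap one nitrogen substituent for another, and both are small. The three numbers together span little more than the scatter, so the series gives no ground to expect a large move in either direction.

Compound 4 is therefore expected to sit close to compound 3, with a step of about a 1.1-fold lower number from compound 3 to compound 4 (0.03 log units; within the scatter), i.e. none beyond the scatter. The estimate for compound 4 is 50000 nM, with a range from 22000 nM to 110000 nM.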

Compound 4, half-maximal inhibitory concentration: "not active" (no number reported)
Compound 4 has no reported number here; there is nothing to compare the estimate with.
By their numbers in this assay, from the lowest: compounds 2, 1 and 3 (each within the scatter of the next, the first and the last beyond it).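

In this assay, going by these compounds alone, compound 4 is reported as "not active" with no number, so no step from compound 3, at 53800 nM, to compound 4 can be read. The compounds shown leave open how far 5,6-dimethoxypyrimidin-4-yl in place of 2,6-dimethoxypyrimidin-4-yl on a sulfonamide nitrogen moves the number. No evidence at hand bears on this result.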